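Methoxy in Place of Fluoro, Tried a Second Time

The source may report more compounds than this note shows. Statements on the series, on what has been measured and on what is new or still open speak of the compounds shown alone.

Three compounds have been measured in an assay on isolated protein for inhibition of DNA topoisomerase 1 (Homo sapiens), with a stated time of 30 min, tested at 20 uM; a lower number here means a weaker effect, a higher number a stronger effect of the compound at the concentration tested:

compound 1 `COc1cccc(-c2nc3ccc(C)cc3c(=O)[nH]2)c1`, giving 0%
compound 2 `Cc1ccc2nc(-c3cccc(F)c3)[nH]c(=O)c2c1`, giving 0.2%
compound 3 `Cc1ccc2c(=O)[nH]c(-c3cccc(F)c3)nc2c1`, giving 4.3%

All three numbers lie within the usual scatter of one another, so none of the three can be set apart from the others on this evidence. Compound 2 and compound 3 are built from the same atoms joined differently; the difference between the two cores is not broken down here. Compound 1 differs from compound 2 by a single change, (methoxy in place of fluoro on an aromatic carbon), and that change made a step of a number 0.2 percentage points lower from compound 2 to compound 1 (within the scatter) in this assay.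

Compound 4 `COc1cccc(-c2nc3cc(C)ccc3c(=O)[nH]2)c1` has not yet been measured. Within the data shown here, it differs from compound 3 by methoxy in place of fluoro on an aromatic carbon, which is the same change as the one from compound 2 to compound 1, at a place described in the same words. Because the earlier step was a number 0.2 percentage points lower from compound 2 to compound 1 (within the scatter), and because compound 3 itself gives only 4.3%, the step from compound 3 to compound 4 is expected to be small, about a number 0.3 percentage points lower from compound 3 to compound 4 (within the scatter). Compound 4 is therefore estimated at 4% in this assay, with a range from 0% to 12% allowing for the scatter of such measurements.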

Compound 4, a percentage reported as inhibition, at one concentration (the size of the read-out at that concentration, not a potency): 80%
Beside the measured number, compound 4's estimate is 76 percentage points below it; measured number above the stated range.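

Among these compounds, on the core of compound 3, methoxy in place of fluoro made a step of a number 75.7 percentage points higher from compound 3 to compound 4 (beyond the scatter) in this assay, so a small step on one core gave no guide to the step on the other. The change therefore did not carry over between these two cores, whose atoms are the same but joined differently: the same change on two cores in this assay, a number 0.2 percentage points lower (within the scatter) from compound 2 to compound 1 and a number 75.7 percentage points higher (beyond the scatter) from compound 3 to compound 4, 75.9 percentage points apart, beyond the scatter of two such steps This shows that in this series the outcome of the change depends on the core that carries it, but it rests on just two cores, gives no rule for any third core, does not explain the difference, and, with a read-out taken at one concentration, says nothing of potency.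

Going by these compounds, it remains open whether the high number is specific to methoxy, or whether a hydroxy group, an amine or a longer ether chain such as ethoxy in its place on the core of compound 4 would also give a number near that of compound 4, the 80% measured here. Also open, on these data alone, is whether the methyl group on the core of compound 4 takes any part in this result, and whether a carboxylic acid or a nitrile there would alter it.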